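This account rests on a few compounds, and the source may have more. Where it says the series, first, only, none or still open, it means among the compounds named here.

Compound 1 `Cc1nc(N2CCCCC2)c2nnn(-c3ccc(C(C)C)cc3Br)c2n1` gives 46 nM in an in vitro assay on 293-EBNA cells for binding affinity to corticotropin-releasing factor receptor 1 (Homo sapiens) (on this read-out higher numbers stand for weaker inhibition and lower numbers for stronger inhibition), the highest of the three numbers recorded there. Compound 2 `CCC(CC)Nc1nc(C)nc2c1nnn2-c1c(C)cc(C)cc1C` gives 5.7 nM in this assay and compound 3 `CCCCC(CC)Nc1nc(C)nc2c1nnn2-c1c(C)cc(C)cc1C` gives 7.6 nM; both carry a secondary amino group where compound 1 carries a cyclic amine, and a differently substituted aryl ring. Going by the values given here, the only measured step, a 1.3-fold higher number from compound 2 to compound 3 (0.12 log units; within the scatter), shows that lengthening the chain on that amino nitrogen changed little. Compound 4 `CCCCN(CC)c1nc(C)nc2c1nnn2-c1ccc(C(C)C)cc1Br` differs from compound 1 by butyl(ethyl)amino in place of piperidin-1-yl on an aromatic carbon. Among the compounds with values here, no measured step bears directly on opening the ring; the step between compound 2 and compound 3 shows only that alkyl chains on this nitrogen are tolerated. Compound 4 is therefore expected to give 20 nM (range 6 nM to 60 nM), an estimated 2.3-fold lower number from compound 1 to compound 4 (0.36 log units; beyond the scatter) that may not exceed the scatter.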

Compound 4, inhibition constant: 7.5 nM
For compound 4 the middle estimate is 2.7-fold (0.43 log units) above the measured one; measured number inside the range.
By their numbers in this assay, from the lowest: compounds 2, 4 and 3 (each within the scatter of the next); then compound 1.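

In this assay, going by these compounds alone, butyl(ethyl)amino in place of piperidin-1-yl on this aromatic carbon gives a 6.1-fold lower number from compound 1 to compound 4 (0.79 log units; beyond the scatter), the first step that lies beyond the scatter. The earlier compounds shown here varied only a chain on a secondary amino nitrogen, whereas this step shows that the ring at this position can be replaced by an open pair of chains with a modest gain. No measurement given here accounts for this gain.

The compounds shown leave open whether the gain follows from opening the ring or from the chains themselves. Diethylamino, dibutylamino or morpholin-4-yl on the same aromatic carbon would bear on that question.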